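The source may report more compounds than this note shows. Statements on the series, on what has been measured and on what is new or still open speak of the compounds shown alone.

Measured so far in a functional assay on HL-60 cells (Homo sapiens) for cytotoxicity, read by MTT assay, with a stated time of 48 h; on this read-out higher numbers stand for weaker inhibition and lower numbers for stronger inhibition:
compound 1 `Fc1cccc(-c2nc(Nc3ccccc3)c3cc(F)ccc3n2)c1`: 48300 nM
compound 2 `COc1ccc(Nc2nc(-c3cccc(F)c3)nc3ccc(F)cc23)cc1`: 38600 nM
compound 3 `Fc1cccc(-c2nc(Nc3ccc(Br)cc3)c3cc(F)ccc3n2)c1`: > 50000 nM, which is a limit of the assay and not a number.

Compound 3 therefore sits at the limit of > 50000 nM in this assay, at which 1 of the 3 values shown sits, so its true value is known only as a floor. Compound 4 `Oc1cccc(Nc2nc(-c3cccc(F)c3)nc3ccc(F)cc23)c1` differs from compound 3 by 3-hydroxyphenyl in place of 4-bromophenyl on a nitrogen on an aromatic ring. The measured steps on the same ring are an at least 1.0-fold higher number from compound 1 to compound 3 (0.01 log units; that floor lies within the scatter), an at least 1.2-fold higher number from compound 2 to compound 3 (0.11 log units; that floor lies within the scatter) and a 1.3-fold lower number from compound 1 to compound 2 (0.10 log units; within the scatter), all within the scatter. Since none of these changes shifted the read-out beyond the scatter, the change to 3-hydroxyphenyl is expected to give at most a comparable step, an at least 1.1-fold lower number from compound 3 to compound 4 (0.04 log units; that floor lies within the scatter), in either direction. Compound 4 is thus estimated at 45000 nM, between 20000 nM and 110000 nM, with a fair chance that again only a limit is reported.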

Compound 4, half-maximal inhibitory concentration: > 50000 nM
Compound 4 was reported as a limit (the forecaster's own chance of this, stated with the estimate: 45%); middle value at least 1.1-fold (0.04 log units) away from the limit.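

Placing a hydrogen-bond donor on the ring, as 3-hydroxyphenyl in place of 4-bromophenyl, still leaves compound 4 at a limit of the assay, as compound 3 is, so the step between these two cannot be read. The steps that can be read give only small floors: an at least 1.2-fold higher number from compound 2 to compound 4 (0.11 log units; that floor lies within the scatter) and an at least 1.0-fold higher number from compound 1 to compound 4 (0.01 log units; that floor lies within the scatter). Values now gather at one end of the scale: the limit of > 50000 nM in this assay, at which 2 of the 4 values shown sit.

As far as these compounds go, whether an amine or a carboxylic acid on this ring would bring a measurable number stays open. So do the true values of compound 3 and compound 4.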